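Series notes: from compound 3 toward compound 4

The source may report more compounds than this note shows. Statements on the series, on what has been measured and on what is new or still open speak of the compounds shown alone.

Measured so far in a functional assay on JAR cells (Homo sapiens) for inhibition, read by MTT assay, with a stated time of 72 h; on this read-out higher numbers stand for weaker inhibition and lower numbers for stronger inhibition:
- compound 1 `CCOC(=O)C1=C(Nc2ccccc2)S/C(=C\c2ccc(O)c(O)c2)C1=O` gives 6100 nM
- compound 2 `CCOC(=O)C1=C(Nc2ccccc2)S/C(=C\c2cc(OC)c(O)c(OC)c2)C1=O` gives 17400 nM
- compound 3 `CCOC(=O)C1=C(Nc2ccc(Br)cc2)S/C(=C\c2ccc[nH]2)C1=O` gives 27000 nM

Compound 3 stands at the highest of the three numbers in this assay. Its nearest neighbour is compound 2, whose number lies within the scatter of that of compound 3, so no order between the two can be read. Compound 1 gives a number that sits beyond the scatter below that of compound 3, and is the only one of the three that is clearly separated from it. Within the data shown here, none of the three measured compounds differs from another in a single place, so no measured step is available.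

Compound 4 `CCOC(=O)C1=C(Nc2ccc([N+](=O)[O-])cc2)S/C(=C\c2ccc[nH]2)C1=O` differs from compound 3 in one place: nitro in place of bromo on an aromatic carbon, which cut one bond further out reads 4-bromophenyl to 4-nitrophenyl. Among the measured compounds shown here, no pair of measured compounds varies this position on its own, so the size and direction of such an exchange are unknown here. The step from compound 3 to compound 4 in this assay is expected to stay within the scatter, a 1.1-fold lower number from compound 3 to compound 4 (0.03 log units; within the scatter). Compound 4 is thus expected to give about 25000 nM in this assay, with a likely range from 8000 nM to 80000 nM.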

Compound 4, half-maximal inhibitory concentration: 15600 nM
Estimate against measurement, compound 4: 1.6-fold (0.20 log units) above; low and high end bracket the measured number.
By their numbers in this assay, from the lowest: compound 1; then compounds 4, 2 and 3 (each within the scatter of the next).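

In this assay, among these compounds, the exchange of bromo for nitro, on an aromatic carbon para to a large group, provides the first measured step at this position: a 1.7-fold lower number from compound 3 to compound 4 (0.24 log units; within the scatter). 4-Bromophenyl and 4-nitrophenyl therefore cannot be told apart in this assay, although the two groups differ in their atoms and nitro carries hydrogen-bond acceptors that bromo lacks, so this pair gives no order and no sign that the position responds to this exchange. No measurement is at hand that bears on the reason for this result.

An amine or a carboxylic acid at this same place could still give a step beyond the scatter, so one exchange within the scatter does not settle how far the position tolerates other groups. Going by these compounds, compound 1 and compound 2 each differ from compound 3 and compound 4 in more than one place, so it remains open whether their numbers owe anything to this position.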